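The source may hold more compounds than are shown below. What is called first, only, known or untested is meant among the compounds shown, and "the series" means these compounds.

Compound 1 `COc1ccc(Cl)cc1C(C)NC(=O)N(C)S(=O)(=O)c1ccc(Cl)cc1`: 20000 nM
Compound 2 `COc1ccc(Cl)cc1C(C)NC(=O)NS(=O)(=O)c1ccc(Cl)cc1`: > 300000 nM, a limit
Compound 3 `COc1ccc(Cl)cc1C(C)NC(=O)NS(=O)(=O)c1ccc(C)cc1`: > 300000 nM, a limit

In a functional assay on thoracic aorta (Rattus norvegicus, strain Wistar), with a stated time of 15 min (a lower number here means that less compound is needed, a higher number that more compound is needed for the effect), compound 2 gives only a limit, > 300000 nM. Compound 4 `COc1ccc(F)cc1C(C)NC(=O)NS(=O)(=O)c1ccc(Cl)cc1` differs from it in one place: fluoro in place of chloro on an aromatic carbon. Going by the values given here, two measured steps bear on this. One is a step that the two limits leave unreadable from compound 2 to compound 3, for methyl in place of chloro on an aromatic carbon. The other, an at least 15-fold higher number from compound 1 to compound 2 (1.17 log units; beyond the scatter), is large but belongs to hydrogen in place of methyl on an amide-type nitrogen, not to a change on an aromatic carbon. Neither gives a readable size for the new change, so no step beyond the scatter is expected in this assay. The estimated step is a number no higher from compound 2 to compound 4 (the limit leaves the size open). Compound 4 is expected at 300000 nM, with an estimated range of 100000 nM to 900000 nM, and a further limit is the likeliest report.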

Compound 4, half-maximal effective concentration: > 300000 nM
Compound 4 was reported as a limit; the forecaster's own chance of this, stated with the estimate: 85%; the middle value lies on the limit itself.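

Compound 2 and compound 4 are both reported as limits in this assay, so no step can be read between them: the limit of > 300000 nM in this assay, at which 3 of the 4 values shown sit.

The compounds shown leave open what size, if any, the step of fluoro in place of chloro has.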